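A few compounds are considered here, and "the series" means these few. Any claim that something is new, unique, unknown or untested is made for them only; others in the source may bear on it.

Working notes on the series. The shared core carries two arylidene arms and an allyl group on the ring nitrogen. Among the compounds with values here, compound 1 `C=CCn1c(=O)/c(=C\c2cccc(F)c2)[nH]c(=O)/c1=C\c1ccccc1OC` is the only member with a number: in a functional assay on MCF7 cells (Homo sapiens) for cytotoxicity, read by CCK-8 assay, with a stated time of 72 h (a higher number here means a weaker inhibitor, a lower number a stronger inhibitor), compound 1 gives 13700 nM. Compound 2 `C=CCn1c(=O)/c(=C\c2ccc(F)c(Br)c2)[nH]c(=O)/c1=C\c1ccccc1OC` is reported in this assay as "not active" (no number reported), with no number. Compound 3 `C=CCn1c(=O)/c(=C\c2cc(OC)c(OC)c(OC)c2)[nH]c(=O)/c1=C\c1cccc(Br)c1` is likewise reported in this assay as "not active" (no number reported). So compound 1 stands as the only quantified point, and the two other entries show only that no activity was found.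

Compound 4 `C=CCn1c(=O)/c(=C\c2ccccc2F)[nH]c(=O)/c1=C\c1ccccc1OC` differs from compound 1 in one place: 2-fluorophenyl in place of 3-fluorophenyl on a double-bonded chain carbon bound to an aromatic carbon. Nothing measured here separates one fluorophenyl from the other, so the step is expected to be small, without a clear direction, and most likely within the usual scatter. For compound 4 in this assay the expected value is 15000 nM, ranging from 5000 nM to 50000 nM. The expected step from compound 1 is a 1.1-fold higher number from compound 1 to compound 4 (0.04 log units; within the scatter).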

Compound 4, half-maximal inhibitory concentration: 23000 nM
Compound 4: the middle estimate sits 1.5-fold (0.19 log units) below what was measured; low and high end bracket the measured number.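

In this assay, 2-fluorophenyl in place of 3-fluorophenyl on a double-bonded chain carbon bound to an aromatic carbon gives a 1.7-fold higher number from compound 1 to compound 4 (0.23 log units; within the scatter), so the two fluorophenyl groups are not told apart at this position. Compound 4 also gives the series a second quantified point, showing that a number in this assay is not unique to compound 1. Nothing available bears on why these two compounds read alike.

The compounds shown leave open whether this position tolerates a group of a different kind, such as an amine or a carboxylic acid on the aromatic ring in place of fluorine. They also leave open what a propyl or longer chain in place of the allyl group on the ring nitrogen would give.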